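Ring-chain dienones on prostate cancer cells: notes

The compounds below may be only part of what the source reports. "The series", "measured", "known", "first", "only" and "open" are said of these compounds alone.

Measured compounds:
compound 1 `COc1ccc(/C=C/C(O)=C/C(=O)/C=C/C2=C(C)CCCC2(C)C)cn1` — in a functional assay on CWR22R cells (Homo sapiens) for cytotoxicity, read by MTT assay, with a stated time of 72 h (on this read-out lower numbers stand for stronger inhibition and higher numbers for weaker inhibition), compound 1 gives "not determined" (no result reported)
compound 2 `CC1=C(/C=C/C(=O)/C(=C\c2ccc(O)cc2)C(=O)/C=C/c2ccc(O)cc2)C(C)(C)CCC1` — in this assay compound 2 gives 4700 nM

For the measured compounds named here, compound 1 stands nowhere on the numbers: this assay reports no value for it, and the only number in hand is that of compound 2. Compound 3 `COc1cc(/C=C/C(O)=C/C(=O)/C=C/C2=C(C)CCCC2(C)C)ccc1O` carries 4-hydroxy-3-methoxyphenyl in place of 6-methoxypyridin-3-yl on a double-bonded chain carbon bound to a double-bonded chain carbon. Going by the values given here, with no measured step around compound 1, no direction for this change can be read from the data; the expected step is small, within the scatter, in either direction. Compound 3 is expected to give 5000 nM, estimated between 1500 nM and 16000 nM.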

Compound 3, half-maximal inhibitory concentration: 10600 nM
For compound 3 the middle estimate is 2.1-fold (0.33 log units) below the measured one; measured number inside the range.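

No step can be read between compound 1 and compound 3: in this assay compound 1 gives "not determined" (no result reported). On these data alone, the effect of exchanging 6-methoxypyridin-3-yl for 4-hydroxy-3-methoxyphenyl stays open, and no further data bear on this result.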